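From Chloro to Isopropyl on the Aromatic Ring

This account rests on a few compounds, and the source may have more. Where it says the series, first, only, none or still open, it means among the compounds named here.

Three compounds share one core and differ only in the group on the six-membered aromatic ring of carbon only. In an ADME assay on LL24 cells (Homo sapiens) for inhibition, read by MTT assay, with a stated time of 24 h (on this read-out higher numbers stand for weaker inhibition and lower numbers for stronger inhibition), compound 1 `CCCc1ccc(C(=O)N/N=C/c2ccc([N+](=O)[O-])o2)cc1` gives 89000 nM. Compound 2 `CC(C)(C)c1ccc(C(=O)N/N=C/c2ccc([N+](=O)[O-])o2)cc1` reaches only a limit of this assay, > 200000 nM. Compound 3 `O=C(N/N=C/c1ccc([N+](=O)[O-])o1)c1ccc(Cl)cc1` gives 187000 nM, the higher of the two plain numbers; its nearest neighbour is compound 1, and the step is a 2.1-fold higher number from compound 1 to compound 3 (0.32 log units; beyond the scatter). On these data alone, compound 4 `CC(C)c1ccc(C(=O)N/N=C/c2ccc([N+](=O)[O-])o2)cc1` is untested: isopropyl in place of chloro on an aromatic carbon. Going by the values given here, two measured steps bear on this change. Exchanging one alkyl group for another gave an at least 2.2-fold higher number from compound 1 to compound 2 (0.35 log units; beyond the scatter), and exchanging an alkyl group for chloro gave a 2.1-fold higher number from compound 1 to compound 3 (0.32 log units; beyond the scatter); between the two weaker compounds the data show an at least 1.0-fold lower number from compound 2 to compound 3 (0.02 log units; that floor lies within the scatter). Isopropyl is an alkyl group like propyl and tert-butyl, so compound 4 is expected to land somewhere between the numbers of compound 1 and compound 2, with a modest drop from compound 3. The estimate for compound 4 is 130000 nM, with a range from 60000 nM to 280000 nM. This expected value means a 1.4-fold lower number from compound 3 to compound 4 (0.16 log units; within the scatter).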

Compound 4, half-maximal inhibitory concentration: > 200000 nM
Compound 4: a limit, no number (the forecaster's own chance of this, stated with the estimate: 25%); middle value at least 1.5-fold (0.18 log units) from the limit.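

In this assay compound 4 reaches only a limit, > 200000 nM, and not a number. Isopropyl in place of propyl on this aromatic carbon gives an at least 2.2-fold higher number from compound 1 to compound 4 (0.35 log units; beyond the scatter), so among the alkyl groups shown only propyl yields a plain number. Isopropyl in place of chloro gives an at least 1.0-fold higher number from compound 3 to compound 4 (0.02 log units; that floor lies within the scatter), so that change shows no readable shift, and the step between compound 2 and compound 4 cannot be read, because both stop at the same limit: the limit of > 200000 nM in this assay, at which 2 of the 4 values shown sit.

On these data alone, how far compound 2 and compound 4 lie past that limit remains unknown. As far as these compounds go, it also remains open whether a longer chain such as butyl, or an amine, at this place would keep, lower or raise the number that compound 1 gives, 89000 nM.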